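The compounds below may be only part of what the source reports. "The series", "measured", "known", "first", "only" and "open" are said of these compounds alone.

In a functional assay on HCT-116 cells (Homo sapiens) for inhibition, read by MTT assay, with a stated time of 72 h; on this read-out higher numbers stand for weaker inhibition of growth and lower numbers for stronger inhibition of growth:
- compound 1 `COc1ccc(-c2nc3c(N4CCN(CC5CC5)CC4)c(Br)cnc3[nH]2)cc1`: 830 nM
- compound 2 `CN(C)c1ccc(-c2nc3c(N4CCN(CC(=O)Nc5ccccc5)CC4)c(Cl)cnc3[nH]2)cc1`: 2550 nM
- compound 3 `CC(c1ccncc1)N1CCN(c2c(Br)cnc3[nH]c(-c4ccc(N(C)C)cc4)nc23)CC1`: 900 nM

Compound 2 has the highest of these three numbers, and its gap to each of the others lies beyond the scatter. Compound 4 `CC(c1ccccc1)N1CCN(c2c(Cl)cnc3[nH]c(-c4ccc(N(C)C)cc4)nc23)CC1` has yet to be measured. It carries 1-phenylethyl in place of (phenylcarbamoyl)methyl on an amine nitrogen in a ring. Among the compounds with values here, no measured pair isolates this change. Compound 3 gives 900 nM and compound 1 gives 830 nM, and neither carries the (phenylcarbamoyl)methyl group. A moderate move towards stronger inhibition in this assay is therefore expected, with an estimated step of a 2.3-fold lower number from compound 2 to compound 4 (0.37 log units; beyond the scatter). For compound 4 the estimated value is 1100 nM, with an expected range from 450 nM to 2600 nM.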

Compound 4, concentration for 50% growth inhibition: 900 nM
Beside the measured number, compound 4's estimate is 1.2-fold (0.09 log units) above it, within the range that was stated.
By their numbers in this assay, from the lowest: compounds 1, 3 and 4 (each within the scatter of the next); then compound 2.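

In this assay, within the data shown here, this pair isolates the change on the amine nitrogen in the ring for the first time: 1-phenylethyl in place of (phenylcarbamoyl)methyl gives a 2.8-fold lower number from compound 2 to compound 4 (0.45 log units; beyond the scatter). Both groups carry one six-membered aromatic ring of carbon only, so the step comes with a change in what links that ring to the nitrogen, with the carbonyl and the amide hydrogen gone. No measurement shown explains the step. From the compounds shown here alone, it remains open how a plain benzyl group or a longer chain ending in the same ring would compare on this nitrogen.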